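Pyrimidine for Phenyl in a Ghrelin Receptor Agonist Series

The source may report more compounds than this note shows. Statements on the series, on what has been measured and on what is new or still open speak of the compounds shown alone.

Compound 1, `COc1ccc(N2C[C@@H](C)N[C@@H](C)C2)cc1NS(=O)(=O)c1ccc(-c2ccccc2)cc1`: 1
Compound 2, `COc1ccc(N2C[C@@H](C)N[C@@H](C)C2)cc1NS(=O)(=O)c1ccc(-c2cnco2)s1`: 0.9

Two compounds share one core and differ only in the aromatic ring attached to the sulfonyl-bearing ring. In a functional assay for agonist activity at growth hormone secretagogue receptor type 1 (Homo sapiens), read by FLIPR (a higher number here means a larger maximal response, a lower number a smaller maximal response), compound 1 gives 1, the full response of the reference agonist. In this assay compound 2 gives 0.9, a number that lies within the usual scatter of that of compound 1, so the two read as alike: both behave as full agonists.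

Compound 3, `COc1ccc(N2C[C@@H](C)N[C@@H](C)C2)cc1NS(=O)(=O)c1ccc(-c2cncnc2)cc1`, is not yet measured. It differs from compound 1 by pyrimidin-5-yl in place of phenyl on an aromatic carbon. For the measured compounds named here, no step between two measured compounds is available for this exact change. Still, the expectation in this assay is a step of no size beyond the scatter, because compound 2 gives 0.9 while carrying an aromatic ring with hetero atoms in place of phenyl, and stays a full agonist.

For compound 3 the estimated value is 0.95, with a range from 0.75 to 1.05. This estimate implies an expected step of a number 0.050 lower from compound 1 to compound 3 (within the scatter), within the scatter.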

Compound 3, intrinsic activity: the largest response reached, as a fraction of the reference agonist's: 0.6
Beside the measured number, compound 3's estimate is 0.35 above it, outside the stated range (below it).
By their numbers in this assay, from the lowest: compound 3; then compounds 2 and 1 (each within the scatter of the next).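

Putting pyrimidin-5-yl in place of phenyl on an aromatic carbon, para to a large group, gives in this assay a step of a number 0.40 lower from compound 1 to compound 3 (beyond the scatter) and shows that this position does not treat all six-membered aromatic rings alike. Both rings have 6 heavy atoms and no net charge; they differ in that 2 nitrogen stand in place of carbon and the entering ring has 2 hydrogen-bond acceptors where phenyl has 0, and this one change leaves compound 3 at 0.6 and so short of a full response. No measurement shown here bears on the reason for this step.

The compounds shown leave open whether a ring with only one nitrogen, such as pyridin-3-yl, would keep the full response of compound 1 or lose part of it as compound 3 does. They also leave open whether the position of the nitrogen matters, as pyrimidin-2-yl would test, and whether a methoxy group or an amine on the pyrimidin-5-yl ring would change the maximal response.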